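Cytotoxicity notes on the series: compound 2 to compound 3

This account rests on a few compounds, and the source may have more. Where it says the series, first, only, none or still open, it means among the compounds named here.

Measured so far:
- compound 1 `Fc1ccc(-c2cn(-c3ccnc4cc(Cl)ccc34)nn2)cc1`: > 3080000 nM, a limit of the test rather than a number
- compound 2 `CCc1ccccc1C(=O)OCc1cn(-c2ccnc3cc(Cl)ccc23)nn1`: > 2550000 nM, a limit of the test rather than a number

In an ADME assay on HepG2 cells (Homo sapiens) for cytotoxicity, read by MTT assay, with a stated time of 24 h (on this read-out lower numbers stand for higher toxicity in this test and higher numbers for lower toxicity in this test), compound 1 gives > 3080000 nM, which is a limit of the test and not a number. Compound 2 gives > 2550000 nM, again a limit and not a number. Among the compounds with values here, compound 2 therefore stands at a limit, and the one other value shown is a limit as well (the limit of > 2550000 nM in this assay, at which 1 of the 2 values shown sits, (the limit of > 3080000 nM in this assay, at which 1 of the 2 values shown sits)). Within the data shown here, no step between two measured compounds is available, so no measured step size can be taken from these two values.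

Compound 3 `COc1ccc(C(=O)OCc2cn(-c3ccnc4cc(Cl)ccc34)nn2)cc1` differs from compound 2 by 4-methoxyphenyl in place of 2-ethylphenyl on a carbonyl carbon. With both measured values sitting at limits, the expectation is a step of no size beyond the scatter, in no particular direction, so the step from compound 2 to compound 3 is estimated at an at least 1.0-fold lower number from compound 2 to compound 3 (0.00 log units; that floor lies within the scatter). Compound 3 is expected to come out near 2500000 nM, between 900000 nM and 5000000 nM, and most probably to be reported only as a limit once more.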

Compound 3, half-maximal cytotoxic concentration: 303000 nM
Compound 3: middle estimate off by 8.3-fold (0.92 log units), on the high side, and the stated range ends above it.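

In this assay, within the data shown here, compound 3 is the first compound to give a number and not a limit, which shows that the group on the carbonyl carbon can shift this read-out within the range of the test. Replacing 2-ethylphenyl with 4-methoxyphenyl at that place gives an at least 8.4-fold lower number from compound 2 to compound 3 (0.92 log units; beyond the scatter), so this single change matters in this test, and the lower number means higher toxicity in this test. Compound 2 stands at a limit, so the step is a floor and its true size cannot be read: the limit of > 2550000 nM in this assay, at which 1 of the 3 values shown sits.

The swap changes both the substituent and its name-position on the ring at once, so the compounds shown do not say whether the lower number goes with the methoxy group or with where it sits; a 4-ethylphenyl or a 2-methoxyphenyl group on the same carbonyl carbon would separate the two. Also open, going by these compounds, is how far the read-out follows the substituent on the ring at all, for which a 4-aminophenyl group or a 4-carboxyphenyl group at this place would give a first answer.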